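The compounds below may be only part of what the source reports. "The series", "measured", "known", "first", "only" and "open" are said of these compounds alone.

Measured compounds:
- Compound 1 `CNCCNC(=O)c1cc(C)nc2c1cnn2C(C)C`: in an ADME assay on Vero cells (Chlorocebus sabaeus) for cytotoxicity, read by neutral red uptake, with a stated time of 3 days (on this read-out higher numbers stand for lower toxicity in this test and lower numbers for higher toxicity in this test), compound 1 gives > 300000 nM, which is a limit of the test rather than a number.
- Compound 2 `Cc1cc(C(=O)NCCN)c2cnn(C(C)C)c2n1`: in this assay compound 2 gives > 300000 nM, again a limit rather than a number.
- Compound 3 `Cc1nn(C(C)(C)C)c2nc(C3CC3)cc(C(=O)NCCN(C)C)c12`: in this assay compound 3 gives 56300 nM, the only plain number among the three.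

The change from compound 1 to compound 2 is hydrogen in place of methyl on an amine nitrogen. Its size in this assay is a step that the two limits leave unreadable from compound 1 to compound 2, since both compounds sit at the limit of > 300000 nM in this assay, at which 2 of the 3 values shown sit. The difference between the core of compound 1 and the core of compound 3 is not broken down here.

Compound 4 `CNCCNC(=O)c1cc(C2CC2)nc2c1c(C)nn2C(C)(C)C` is not yet measured. Among the measured compounds shown here, it arises from compound 3 by hydrogen in place of methyl on an amine nitrogen, the same kind of change as the one from compound 1 to compound 2, though not the same: in compound 1 the amine nitrogen has one other neighbour, a saturated chain carbon, while in compound 3 its other neighbours are two saturated chain carbons. The earlier step gives no readable size to lean on, so the expectation for compound 4 rests mainly on the value of compound 3, 56300 nM, treated as the starting point.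

The step from compound 3 to compound 4 in this assay is expected to be a 1.4-fold higher number from compound 3 to compound 4 (0.15 log units; within the scatter), a change small enough to fall within ordinary scatter. Compound 4 is therefore estimated to give about 80000 nM in this assay, with a plausible range from 30000 nM to 300000 nM.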

Compound 4, half-maximal cytotoxic concentration: 36800 nM
For compound 4 the middle estimate is 2.2-fold (0.34 log units) above the measured one; low and high end bracket the measured number.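

In this assay, replacing methyl with hydrogen on the amine nitrogen, which turns 2-(dimethylamino)ethyl into 2-(methylamino)ethyl, gives a 1.5-fold lower number from compound 3 to compound 4 (0.18 log units; within the scatter), so on the core of compound 3 this change has no effect that can be told apart from ordinary repeat variation. On the core of compound 1 the same kind of change cannot be read, as compound 1 and compound 2 each give a limit of the test rather than a number: the limit of > 300000 nM in this assay, at which 2 of the 4 values shown sit. This leaves a single readable step with no second size to set beside it, so the data do not show whether the change behaves alike on the two cores, only that it makes no measurable difference on the core of compound 3.

The compounds shown leave open whether a larger group on the amine nitrogen, such as ethyl, a ring amine such as piperidine, or a longer chain in place of the ethyl link would give a step beyond the scatter. Compound 1 and compound 4 also differ in more than one place, so which part of the core difference matters in this assay remains unresolved.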